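Working notes: removing the methoxy from compound 3

The source may hold more compounds than are shown below. What is called first, only, known or untested is meant among the compounds shown, and "the series" means these compounds.

Measured so far:
compound 1 `COc1ccc(S(=O)(=O)c2cnc3ccc(F)cc3c2N2CCC(C)CC2)cc1`: 85%
compound 2 `CC1CCN(c2c(S(=O)(=O)c3ccc(F)c(Cl)c3)cnc3cc(F)ccc23)CC1`: 94%
compound 3 `COc1ccc(S(=O)(=O)c2cnc3ccc(C)cc3c2N2CCC(C)CC2)cc1`: 62%

In an assay on isolated protein for displacement of a labelled ligand from metabotropic glutamate receptor 5 (Homo sapiens), with a stated time of 60 min, tested at 1 uM (a lower number here means less inhibition, a higher number more inhibition at the concentration tested (going by the name of the read-out)), compound 3 stands lowest of the three numbers. Compound 1 sits higher by a margin beyond the scatter, and compound 2 higher still, also beyond the scatter. For the measured compounds named here, the only single-point step measured is a number 23 percentage points lower from compound 1 to compound 3 (beyond the scatter); it concerns the ring that carries the fluoro or methyl, not the sulfonyl-bound ring, so it says nothing direct about the next change.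

Compound 4 `Cc1ccc2ncc(S(=O)(=O)c3ccccc3)c(N3CCC(C)CC3)c2c1` differs from compound 3 in one place: hydrogen in place of methoxy on an aromatic carbon. Going by the values given here, no measured pair isolates this change, and compound 2 carries a differently substituted sulfonyl-bound ring together with a different fluoro position, so its value cannot be read as a guide. Without a bearing step the expected step of a number 4 percentage points lower from compound 3 to compound 4 (within the scatter) is set near zero with a wide range. Compound 4 is therefore estimated at 58%, between 30% and 85%.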

Compound 4, a percentage reported as inhibition, at one concentration (the size of the read-out at that concentration, not a potency): 67%
The estimate for compound 4 lay 9 percentage points below the measured number, and the stated range covers the measured number.
By their numbers in this assay, from the lowest: compounds 3 and 4 (each within the scatter of the next); then compounds 1 and 2 (each within the scatter of the next).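

In this assay, for the compounds shown here, the change from 4-methoxyphenyl to phenyl gives a number 5 percentage points higher from compound 3 to compound 4 (within the scatter), the first reading for this position, para to a large group. With the methyl-bearing core of compound 3, methoxy can therefore be replaced by hydrogen with no change beyond the scatter. No available evidence bears on this result.

On these data alone, whether the same replacement holds with the fluoro on the core of compound 1 remains open. So does the effect on the number of an amine or a carboxylic acid at this position.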